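Aryloxy variation on the shared core: compound 3 to compound 4

A few compounds are considered here, and "the series" means these few. Any claim that something is new, unique, unknown or untested is made for them only; others in the source may bear on it.

Compound 1 `Cn1c(CN2C[C@@H]3C(COc4ccccc4)[C@@H]3C2)nc2ccccc21` — in an in vitro assay on HEK293 cells with metabotropic glutamate receptor 2 (Rattus norvegicus) as the target, read by FLIPR, in the presence of a further agent that is not named here (on this read-out lower numbers stand for an effect already at smaller amounts and higher numbers for an effect only at larger amounts of compound), compound 1 gives 24 nM.
Compound 2 `Cn1c(CN2C[C@@H]3C(COc4cc(F)ccc4F)[C@@H]3C2)nc2ccccc21` — in this assay compound 2 gives 7 nM.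
Compound 3 `Cn1c(CN2C[C@@H]3C(COc4ccc(Cl)cn4)[C@@H]3C2)nc2ccccc21` — in this assay compound 3 gives 26 nM.

Compound 3 has the highest number of the three in this assay. Its nearest neighbour is compound 1: the step of a 1.1-fold higher number from compound 1 to compound 3 (0.03 log units; within the scatter) lies within the scatter, so the two are not told apart. Compound 2 is the furthest: the step of a 3.7-fold higher number from compound 2 to compound 3 (0.57 log units; beyond the scatter) is modest and beyond the scatter, as is a 3.4-fold lower number from compound 1 to compound 2 (0.54 log units; beyond the scatter).

Compound 4 `Cn1c(CN2C[C@@H]3C(COc4ccc(Cl)nc4)[C@@H]3C2)nc2ccccc21` differs from compound 3 in one place: 6-chloropyridin-3-yl in place of 5-chloropyridin-2-yl on an oxygen on a saturated carbon. Within the data shown here, none of the measured steps covers this kind of change; the steps that do exist swap phenyl for 2,5-difluorophenyl or for 5-chloropyridin-2-yl on the same oxygen, and the pyridinyl case sat within the scatter of phenyl. Among the measured compounds shown here, the only change beyond the scatter came from the difluorophenyl of compound 2, which does not enter here. The expectation for compound 4 in this assay is therefore a step of a 1.0-fold lower number from compound 3 to compound 4 (0.02 log units; within the scatter) that stays within the scatter. Compound 4 is estimated at 25 nM, with a range of 10 nM to 65 nM.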

Compound 4, half-maximal effective concentration: 511 nM
Compound 4: the middle estimate sits 20-fold (1.31 log units) below what was measured; measured number outside the range, above it.
By their numbers in this assay, from the lowest: compound 2; then compounds 1 and 3 (each within the scatter of the next); then compound 4.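

In this assay the group on this oxygen turns out to be sensitive to how its atoms are joined, not only to which atoms it holds: with the same atoms in both compounds, the change is large (a 20-fold higher number from compound 3 to compound 4 (1.29 log units; beyond the scatter)), whereas the swap of phenyl for 5-chloropyridin-2-yl lay within the scatter (a 1.1-fold higher number from compound 1 to compound 3 (0.03 log units; within the scatter)). So a chloropyridinyl group as such is not what sets the number, as one isomer cannot be told apart from phenyl and the other stands well away from it (a 21-fold higher number from compound 1 to compound 4 (1.33 log units; beyond the scatter)). The 6-chloropyridin-3-yl group also lies far from 2,5-difluorophenyl (a 73-fold higher number from compound 2 to compound 4 (1.86 log units; beyond the scatter)), which makes this the widest step in the set and compound 4 the compound with the highest number.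

The two chloropyridinyl groups differ in how the ring nitrogen and the chlorine are placed relative to the oxygen, and the compounds shown cannot separate these two, so it stays open whether an unsubstituted pyridinyl, or a methoxy or nitrile in place of the chlorine, would follow compound 3 or compound 4. Nothing available bears on the cause of this step.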